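The compounds below may be only part of what the source reports. "The series", "measured", "known", "first", "only" and "open" are said of these compounds alone.

Measured compounds:
- compound 1 `CC(=O)N1N=C(c2cc(O)c(O)c([N+](=O)[O-])c2)CC1c1ccco1` gives 98000 nM
- compound 2 `N#Cc1ccc(/C=C/C(=O)c2cc(O)c(O)c([N+](=O)[O-])c2)cc1` gives 45300 nM

Both compounds were tested in an assay on isolated protein for inhibition of Amine oxidase [flavin-containing] A (Homo sapiens), read by fluorescence; a lower number here means a stronger inhibitor, a higher number a weaker inhibitor. Compound 1 gives 98000 nM, the higher of the two numbers, which marks it as the weaker inhibitor of the pair. Compound 2 gives 45300 nM, and the gap between the two lies beyond the usual scatter of this assay. The two structures differ in more than one place, so no single structural change can be tied to that gap.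

Compound 3 `CC(=O)N1N=C(c2cc(O)c(O)c([N+](=O)[O-])c2)CC1c1nccs1` has not yet been measured in this assay. It differs from compound 1 in one place only: 1,3-thiazol-2-yl in place of furan-2-yl on a saturated ring carbon. Among the compounds with values here, nothing among the measured compounds shows what such an exchange does here, so the expectation rests on the value of compound 1 alone. One five-membered aromatic ring is swapped for another of the same size, and the step from compound 1 to compound 3 is expected to be small, a 1.2-fold lower number from compound 1 to compound 3 (0.09 log units; within the scatter), and quite possibly within the scatter. Compound 3 is therefore expected to give about 80000 nM, with a plausible range from 30000 nM to 200000 nM.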

Compound 3, half-maximal inhibitory concentration: 84600 nM
Beside the measured number, compound 3's estimate is 1.1-fold (0.02 log units) below it, within the range that was stated.
By their numbers in this assay, from the lowest: compounds 2, 3 and 1 (each within the scatter of the next, the first and the last beyond it).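

In this assay, putting 1,3-thiazol-2-yl in place of furan-2-yl on the saturated ring carbon gives a 1.2-fold lower number from compound 1 to compound 3 (0.06 log units; within the scatter). Compounds 1 and 3 are the first pair shown that differs in one place only, so this is the first direct reading of any change at this position, and the two compounds cannot be told apart. A ring with one hetero atom and one hydrogen-bond acceptor and a ring with two hetero atoms and two hydrogen-bond acceptors, each with the same number of heavy atoms, therefore read alike here, and no measurement at hand bears on why that is so.

Both groups compared at this position are five-membered aromatic rings, so the compounds shown leave open what a six-membered phenyl ring, a simple amine such as piperidine or a carboxylic acid would do there. Going by these compounds, the acetyl group on the ring nitrogen and the nitro-bearing catechol ring stay the same in compounds 1 and 3, so it also remains open how a longer acyl chain such as butanoyl, or a change to that ring, would affect the number.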